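Cyclohexyl to 2,4-dimethylphenyl swap at two attachment sites

A few compounds are considered here, and "the series" means these few. Any claim that something is new, unique, unknown or untested is made for them only; others in the source may bear on it.

Of the compounds shown here, three have been measured in a functional assay on MCF7 cells (Homo sapiens) for antiproliferative activity, read by MTT assay, with a stated time of 48 h; a higher number here means a weaker inhibitor, a lower number a stronger inhibitor. Compound 1 `CCCCCCN(C(C)=O)c1ccc(NC(C)=O)cc1SCC1CCCCC1` gives 20400 nM. Compound 2 `CCCCCCN(C(C)=O)c1ccc(NC(C)=O)cc1SCc1ccc(C)cc1C` gives 20700 nM, and compound 3 `CCCCCCSc1cc(NC(C)=O)ccc1N(CC1CCCCC1)C(C)=O` gives 21000 nM. The change from compound 1 to compound 2 is 2,4-dimethylphenyl in place of cyclohexyl on a saturated chain carbon bound to a sulfur and produced a 1.0-fold higher number from compound 1 to compound 2 (0.01 log units; within the scatter). The difference between the core of compound 1 and the core of compound 3 is not broken down here: the two hold the same atoms, joined differently.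

Compound 4 `CCCCCCSc1cc(NC(C)=O)ccc1N(Cc1ccc(C)cc1C)C(C)=O` is not yet measured. It differs from compound 3 by 2,4-dimethylphenyl in place of cyclohexyl on a saturated chain carbon bound to an amide-type nitrogen. This is the same kind of change as the earlier one, not the same, since the ring there sits on a saturated chain carbon bound to a sulfur, here on a saturated chain carbon bound to an amide-type nitrogen. Because the earlier step was a 1.0-fold higher number from compound 1 to compound 2 (0.01 log units; within the scatter), and all three measured values lie within the scatter of one another, the expected step for compound 4 is no change at the digits printed from compound 3 to compound 4 (within the scatter). The estimated value for compound 4 in this assay is 21000 nM, expected between 10000 nM and 45000 nM.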

Compound 4, half-maximal inhibitory concentration: 21600 nM
Beside the measured number, compound 4's estimate is 1.0-fold (0.01 log units) below it; the range from low to high includes it.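

In this assay, 2,4-dimethylphenyl in place of cyclohexyl on a saturated chain carbon bound to an amide-type nitrogen gives a 1.0-fold higher number from compound 3 to compound 4 (0.01 log units; within the scatter), and the change reads alike on the two cores: the same change on two cores in this assay, a 1.0-fold higher number (0.01 log units; within the scatter) from compound 1 to compound 2 and a 1.0-fold higher number (0.01 log units; within the scatter) from compound 3 to compound 4, 1.0-fold (0.01 log units) apart, within the scatter of two such steps So, in these two pairs, the swap carries from the core of compound 1 to the core of compound 3 without a shift that can be told from the scatter. This does not show that the change is transferable in general, and a step this small says nothing about how either ring contributes to activity.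

Open, as far as these compounds go, is whether any replacement at these sites moves the number beyond the scatter. An amine, a carboxylic acid or a longer chain in place of the ring lies outside the compounds shown.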